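Methylamino for cyclopropyl on the shared core of compound 2

The compounds below may be only part of what the source reports. "The series", "measured", "known", "first", "only" and "open" are said of these compounds alone.

Measured compounds:
compound 1 `Cc1ncncc1-c1nc2cc(F)c(F)cc2n1C1CC1`: 17 nM
compound 2 `Fc1cc2nc(-c3cncnc3C3CC3)n(C3CC3)c2cc1F`: 172 nM

In an assay on cells for inhibition of cytochrome P450 11B2, mitochondrial (Homo sapiens), read by HPLC, with a stated time of 90 min (a lower number here means a stronger inhibitor, a higher number a weaker inhibitor), compound 1 gives 17 nM. In this assay, within the data shown here, compound 2 gives 172 nM, the highest of the two numbers; its nearest neighbour is compound 1, and the single measured step, a 10-fold higher number from compound 1 to compound 2 (1.01 log units; beyond the scatter), separates them. Compound 3 `CNc1ncncc1-c1nc2cc(F)c(F)cc2n1C1CC1` has not yet been measured. It differs from compound 2 in one place: methylamino in place of cyclopropyl on an aromatic carbon. Among the measured compounds shown here, the group that enters is neither the methyl of compound 1 nor the cyclopropyl of compound 2, so no measured step covers this exchange directly. For the measured compounds named here, the only step that bears on it is a 10-fold higher number from compound 1 to compound 2 (1.01 log units; beyond the scatter), which shows that a change at this carbon can move the number well beyond the scatter. With the cyclopropyl leaving compound 2, the expectation is a step back toward the lower numbers, with wide uncertainty. Compound 3 is therefore estimated at 40 nM in this assay, with a range from 10 nM to 200 nM, which corresponds to an expected step of a 4.3-fold lower number from compound 2 to compound 3 (0.63 log units; beyond the scatter).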

Compound 3, half-maximal inhibitory concentration: < 2 nM
Compound 3 was reported as a limit; the forecaster's own chance of this, stated with the estimate: 5%; middle value at least 20-fold (1.30 log units) away from the limit.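

Compound 3 stands in this assay only as a limit and not as a number: the limit of < 2 nM in this assay, at which 1 of the 3 values shown sits.

Before this result, the only change shown at this aromatic carbon, next to the ring nitrogen, was one that raised the number, so it was unknown whether any group there could improve on the methyl of compound 1. The new steps show that one can, with an at least 8.5-fold lower number from compound 1 to compound 3 (0.92 log units; beyond the scatter) and, measured against the cyclopropyl compound, an at least 86-fold lower number from compound 2 to compound 3 (1.93 log units; beyond the scatter). Of the three groups shown at this carbon, only methylamino holds a nitrogen and a hydrogen-bond donor, but three compounds cannot separate the contribution of either feature from that of the group as a whole.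

The limit leaves the full size of both steps open, and it also leaves compound 3 without a number that could be set against any later change at this carbon. The compounds shown also leave open whether the hydrogen on the nitrogen matters, which a dimethylamino group, a methoxy group or an unsubstituted amine at the same carbon would begin to address.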